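The source may hold more compounds than are shown below. What is called first, only, known or untested is meant among the compounds shown, and "the series" means these compounds.

Of the compounds shown here, two built on one shared core have been measured so far. Compound 1 `O=C(Nc1ccc(C(F)(F)F)cc1)C1CCc2ccccc2N1` carries a trifluoromethyl on the amide-bearing ring, and in a functional assay on NCI-H23 cells (Homo sapiens) for cytotoxicity, read by sulforhodamine B assay, with a stated time of 72 h (on this read-out lower numbers stand for stronger inhibition of growth and higher numbers for weaker inhibition of growth), compound 1 gives 25800 nM. Compound 2 `O=C(Nc1ccccc1O)C1CCc2ccccc2N1` carries a hydroxy there instead, and in this assay compound 2 gives 2230 nM, the lowest of the two numbers, with compound 1 standing above it by a gap beyond the usual scatter. Compound 3 `O=C(Nc1ccccc1)C1CCc2ccccc2N1` has not yet been measured. Going by the values given here, its one change from compound 2 is hydrogen in place of hydroxy on an aromatic carbon. Among the compounds with values here, no step between two measured compounds is known here, so the effect of removing the hydroxy can only be guessed. Compound 3 is expected to shift toward weaker inhibition by a 2.7-fold higher number from compound 2 to compound 3 (0.43 log units; beyond the scatter). Compound 3 is therefore estimated at 6000 nM, within a range from 1500 nM to 25000 nM.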

Compound 3, concentration for 50% growth inhibition: 97100 nM
Estimate against measurement, compound 3: 16-fold (1.21 log units) below; the measured number lies above the stated range.
By their numbers in this assay, from the lowest: compound 2; then compound 1; then compound 3.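

In this assay, hydrogen in place of hydroxy on an aromatic carbon, ortho to a large group, gives a 44-fold higher number from compound 2 to compound 3 (1.64 log units; beyond the scatter), so a single oxygen atom at this place makes a large difference to growth inhibition. Hydrogen in place of trifluoromethyl also raises the number, giving a 3.8-fold higher number from compound 1 to compound 3 (0.58 log units; beyond the scatter), which makes compound 3 the weakest of the three and shows that both groups go with stronger inhibition than hydrogen, though by steps of very different size. No measurement here explains either step.

An amine or a methoxy group on the same aromatic carbon would show whether anything other than hydroxy can hold this gain. As far as these compounds go, it also remains open how much of the gain would survive if the hydroxy sat on a different carbon of that ring.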